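Swapping the ring-nitrogen substituent in a weakly cytotoxic series

A few compounds are considered here, and "the series" means these few. Any claim that something is new, unique, unknown or untested is made for them only; others in the source may bear on it.

Compound 1 `COc1ccc(-c2cn3cc(C4=CCN(S(=O)(=O)C5CCCCC5)CC4)ccc3n2)cc1OC`: 75000 nM
Compound 2 `COc1ccc(-c2cn3cc(C4=CCN(C(=O)C5CC5)CC4)ccc3n2)cc1OC`: 77600 nM

In an ADME assay on HEK293 cells (Homo sapiens) for cytotoxicity, read by MTT assay, with a stated time of 48 h (a lower number here means a stronger inhibitor, a higher number a weaker inhibitor), compound 1 gives 75000 nM, the lowest of the two numbers shown, and compound 2 gives 77600 nM, a number within the scatter of compound 1. Within the data shown here, the one measured step, a 1.0-fold higher number from compound 1 to compound 2 (0.01 log units; within the scatter), shows that replacing the cyclohexylsulfonyl on the ring nitrogen with a small carbonyl group left the read-out essentially unchanged.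

Compound 3 `COc1ccc(-c2cn3cc(C4=CCN(C(=O)c5cccs5)CC4)ccc3n2)cc1OC` carries the same shared core. The change from compound 1 is (thiophen-2-yl)carbonyl in place of cyclohexylsulfonyl on an amine nitrogen in a ring. This step has the same place and the same leaving group as the measured step, so that step is the relevant guide, and it was flat. No shift beyond the scatter is therefore expected: the step from compound 1 to compound 3 is estimated as a 1.1-fold lower number from compound 1 to compound 3 (0.03 log units; within the scatter). Compound 3 is expected to give about 70000 nM in this assay, with a likely range from 30000 nM to 160000 nM.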

Compound 3, half-maximal inhibitory concentration: 98100 nM
Estimate against measurement, compound 3: 1.4-fold (0.15 log units) below; measured number inside the range.
By their numbers in this assay, from the lowest: compounds 1, 2 and 3 (each within the scatter of the next).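

With (thiophen-2-yl)carbonyl in place of cyclohexylsulfonyl, the result is a 1.3-fold higher number from compound 1 to compound 3 (0.12 log units; within the scatter) and so stays flat even when an aromatic ring enters at this amine nitrogen. The comparison with the cyclopropyl amide isolates the group on the carbonyl carbon, and thiophen-2-yl in place of cyclopropyl gives a 1.3-fold higher number from compound 2 to compound 3 (0.10 log units; within the scatter) as a second step within the scatter. In this assay these three uncharged groups therefore cannot be told apart, and no supporting data offer an explanation for this flatness.

The compounds shown leave open whether a group carrying a basic amine or a carboxylic acid at this nitrogen would move the number beyond the scatter. They also leave open how much of the weak cytotoxicity comes from the shared core, which is identical in all three compounds.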